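Ring swap on the amide nitrogen: compound 3 to compound 4

A few compounds are considered here, and "the series" means these few. Any claim that something is new, unique, unknown or untested is made for them only; others in the source may bear on it.

Measured so far in an ADME assay on HepG2 2.2.15 cells (Homo sapiens) for cytotoxicity, read by MTT assay, with stated times of 48 h and 9 days; on this read-out lower numbers stand for higher toxicity in this test and higher numbers for lower toxicity in this test:
compound 1 `COc1ccc2c(=O)c(/C=C/C(=O)Nc3cccc(C)c3)coc2c1` gives 554000 nM
compound 2 `COc1ccc2c(=O)c(/C=C/C(=O)NCc3ccccc3)coc2c1` gives 376000 nM
compound 3 `COc1ccc2c(=O)c(/C=C/C(=O)NCc3cccc(F)c3)coc2c1` gives 475000 nM

Compound 3 stands within the scatter of both others in this assay, as the steps of a 1.2-fold lower number from compound 1 to compound 3 (0.07 log units; within the scatter) and a 1.3-fold higher number from compound 2 to compound 3 (0.10 log units; within the scatter) show. Compound 4 `COc1ccc2c(=O)c(/C=C/C(=O)Nc3ccccc3OC)coc2c1` differs from compound 3 by 2-methoxyphenyl in place of 3-fluorobenzyl on an amide-type nitrogen. Among the compounds with values here, the steps that bear on this change are those that replaced the group on the amide-type nitrogen, a 1.5-fold lower number from compound 1 to compound 2 (0.17 log units; within the scatter) and a 1.2-fold lower number from compound 1 to compound 3 (0.07 log units; within the scatter), and neither went beyond the scatter; compound 1, which also carries an aromatic ring directly on that nitrogen, sits with the rest. No step beyond the scatter in this assay is therefore expected, and the estimated step is a 1.0-fold higher number from compound 3 to compound 4 (0.00 log units; within the scatter). Compound 4 is expected at 480000 nM, with a range from 240000 nM to 960000 nM.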

Compound 4, half-maximal cytotoxic concentration: 1050000 nM
Estimate against measurement, compound 4: 2.2-fold (0.34 log units) below, and the stated range ends below it.
By their numbers in this assay, from the lowest: compounds 2, 3, 1 and 4 (each within the scatter of the next, the first and the last beyond it).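

In this assay, no earlier change on the amide-type nitrogen had gone beyond the scatter, but 2-methoxyphenyl does so against both benzyl-type groups (a 2.2-fold higher number from compound 3 to compound 4 (0.34 log units; beyond the scatter); a 2.8-fold higher number from compound 2 to compound 4 (0.45 log units; beyond the scatter)). Against the 3-methylphenyl group, which also places an aromatic ring directly on that nitrogen, the step stays within the scatter (a 1.9-fold higher number from compound 1 to compound 4 (0.28 log units; within the scatter)). No measurement shown accounts for this difference.

The compounds shown do not separate the effect of the methoxy group from that of attaching the ring directly to the nitrogen. From the compounds shown here alone, how a pyridine ring, an amine-bearing phenyl group or a longer chain on that nitrogen would read remains open.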